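The source may report more compounds than this note shows. Statements on the series, on what has been measured and on what is new or still open speak of the compounds shown alone.

In a functional assay on A549 cells (Homo sapiens) for inhibition, read by MTT assay, with a stated time of 72 h (a higher number here means a weaker inhibitor, a lower number a stronger inhibitor), compound 1 `Cc1nc(-c2ccc(F)cc2)c(C(=O)N2CCN(c3cc(Cl)cc(Cl)c3)CC2)o1` gives 296 nM and compound 2 `COc1cc(OC)cc(N2CCN(C(=O)c3oc(C)nc3-c3ccccc3F)CC2)c1` gives 27 nM. Compound 2 therefore holds the lower of the two numbers, and the gap between them lies beyond the usual scatter of repeated measurements. Compound 3 `COc1cc(OC)cc(N2CCN(C(=O)c3oc(C)nc3-c3ccc(F)cc3)CC2)c1` keeps everything in compound 2 except one group: on an aromatic carbon, 4-fluorophenyl stands in place of 2-fluorophenyl (4-fluorophenyl in place of 2-fluorophenyl on an aromatic carbon). The two compounds have the same atoms, joined differently.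

Among the compounds with values here, no measured pair shows this change on its own, so any expectation is loose. Within the data shown here, the only measured compound with 4-fluorophenyl is compound 1 at 296 nM, but it also differs from compound 2 elsewhere, so that value cannot be read as the effect of this swap. Because compound 2 gives 27 nM and the rest of the structure is unchanged, compound 3 should stay nearer to that number, with a modest drift toward a higher number. The expected change is a 1.9-fold higher number from compound 2 to compound 3 (0.27 log units; within the scatter) in this assay, a step that may not clear the scatter by much. Compound 3 is estimated at about 50 nM, with an expected range from 14 nM to 190 nM.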

Compound 3, half-maximal inhibitory concentration: 158 nM
Beside the measured number, compound 3's estimate is 3.2-fold (0.50 log units) below it; the range from low to high includes it.
By their numbers in this assay, from the lowest: compound 2; then compounds 3 and 1 (each within the scatter of the next).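

Within the data shown here, compound 2 and compound 3 give the first clean reading of this position: with the rest of the structure unchanged, 4-fluorophenyl in place of 2-fluorophenyl on an aromatic carbon of the five-membered aromatic ring gives a 5.9-fold higher number from compound 2 to compound 3 (0.77 log units; beyond the scatter) in this assay, so where the fluorine sits on this phenyl ring matters even though the atoms stay the same. The other single change, 3,5-dimethoxyphenyl in place of 3,5-dichlorophenyl on the ring amine nitrogen, gives a 1.9-fold lower number from compound 1 to compound 3 (0.27 log units; within the scatter), so with 4-fluorophenyl present, this swap cannot be told apart from the scatter. Nothing available explains why moving the fluorine changes the number.

On these data alone, the 2-fluorophenyl group appears here only with 3,5-dimethoxyphenyl, so it remains open whether it would bring a similar gain alongside 3,5-dichlorophenyl. Also open, as far as these compounds go, is how this position would respond to other groups, such as an unsubstituted phenyl or a 2-chlorophenyl, which could show whether fluorine itself is needed to reach a number as low as that of compound 2.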